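This account rests on a few compounds, and the source may have more. Where it says the series, first, only, none or still open, it means among the compounds named here.

Three compounds have been measured in a functional assay on NCI-H3122 cells (Homo sapiens) for inhibition, read by CellTiter-Glo, with a stated time of 72 h; on this read-out lower numbers stand for stronger inhibition of growth and higher numbers for weaker inhibition of growth:

Compound 1 `C=CC(=O)Nc1cc(Nc2ncc(Cl)c(Nc3ccccc3S(=O)(=O)C(C)C)n2)c(OC)cc1N1CCC(N2CCN(C)CC2)CC1` gives < 0.3 nM.
Compound 2 `C=CC(=O)Nc1cc(Nc2ncc(Cl)c(Nc3ccccc3S(=O)(=O)C(C)C)n2)c(OC)cc1N1CCCN(C)CC1` gives < 0.3 nM.
Compound 3 `C=CC(=O)Nc1cc(Nc2ncc(Cl)c(Nc3ccccc3S(=O)(=O)C(C)C)n2)c(OC)cc1N1CCN(C(C)C)CC1` gives < 0.3 nM.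

Each of these three readings is a limit of the assay, not a number. Compound 3 therefore stands at the limit, and the same holds for the other two, since (the limit of < 0.3 nM in this assay, at which 3 of the 3 values shown sit). Among the compounds with values here, the one step between compounds that differ in a single place, a step that the two limits leave unreadable from compound 2 to compound 3, cannot be sized for that reason.

Compound 4 `C=CC(=O)Nc1cc(Nc2ncc(Cl)c(Nc3ccccc3S(=O)(=O)C(C)C)n2)c(OC)cc1N1CCCCC1` is the next compound. It differs from compound 3 in one place: piperidin-1-yl in place of 4-isopropylpiperazin-1-yl on an aromatic carbon. Within the data shown here, no measured step touches this kind of change; the only measured step is the unreadable one from compound 2 to compound 3. So there is no direct guide to how large the step in this assay will be, or in which direction. What is known is that three variations of the group at this position all sit at the limit, which suggests the position tolerates change, but a piperidine has not been tried.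

My estimate is that compound 4 comes in at 1 nM, within 0.3 nM to 5 nM, and that the expected step of an at least 3.3-fold higher number from compound 3 to compound 4 (0.52 log units; beyond the scatter) is small, if any.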

Compound 4, concentration for 50% growth inhibition: 29 nM
Compound 4: the middle estimate sits 29-fold (1.46 log units) below what was measured; measured number above the stated range.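

The three earlier readings suggested that this position accepts almost any ring amine, but in this assay it does not: piperidin-1-yl in place of 4-isopropylpiperazin-1-yl gives an at least 96-fold higher number from compound 3 to compound 4 (1.98 log units; beyond the scatter), and piperidin-1-yl in place of 4-methyl-1,4-diazepan-1-yl gives an at least 96-fold higher number from compound 2 to compound 4 (1.98 log units; beyond the scatter). Compound 1 carries a piperidine ring here as well, yet hydrogen in place of its 4-methylpiperazin-1-yl gives an at least 96-fold higher number from compound 1 to compound 4 (1.98 log units; beyond the scatter), so the piperidine ring alone does not account for the loss, and among these four compounds only compound 4 has no second nitrogen in this group. These steps give only the smallest possible size of each change because compounds 1, 2 and 3 all sit at the same assay limit: the limit of < 0.3 nM in this assay, at which 3 of the 4 values shown sit.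

Going by these compounds, the steps among compounds 1, 2 and 3 cannot be read, so any order among those groups remains unknown. On these data alone, it also remains open whether the second nitrogen itself matters or only the extra heavy atoms, a question that a morpholin-4-yl ring or a 4-(dimethylamino)piperidin-1-yl group at this place could help to answer.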